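The source may hold more compounds than are shown below. What is called first, only, known or untested is meant among the compounds shown, and "the series" means these compounds.

Compound 1 `c1cn(-c2ncnc3c2cnn3CCN2CCCCC2)cn1` in an assay on HEK293 cells for displacement of a labelled ligand from Sigma non-opioid intracellular receptor 1 (Homo sapiens), read by scintillation counting, with a stated time of 120 min; a higher number here means a weaker inhibitor, a lower number a stronger inhibitor: 13800 nM
Compound 2 `CCOc1ccccc1-c1ncnc2c1cnn2CCN1CCCCC1` in this assay: 300 nM

Compound 2 has the lower of the two numbers; compound 1 sits far higher, a gap well beyond the usual scatter. Compound 3 `Clc1ccccc1-c1ncnc2c1cnn2CCN1CCCCC1` keeps the shared core and its chain and changes one group on the six-membered ring: chloro in place of ethoxy on an aromatic carbon. For the measured compounds named here, no measured pair shows this exchange, so the expectation rests on compound 2 alone. The step is expected to be small, within the scatter or a little upward: a 1.7-fold higher number from compound 2 to compound 3 (0.22 log units; within the scatter). Compound 3 is estimated at 500 nM, within 120 nM to 2000 nM.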

Compound 3, inhibition constant: 76 nM
Compound 3: middle estimate off by 6.6-fold (0.82 log units), on the high side; measured number outside the range, below it.
By their numbers in this assay, from the lowest: compound 3; then compound 2; then compound 1.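

In this assay, chloro in place of ethoxy on this aromatic carbon gives a 3.9-fold lower number from compound 2 to compound 3 (0.60 log units; beyond the scatter), so the oxygen and ethyl part of ethoxy are not needed here for a low number. 2-Chlorophenyl in place of 1H-imidazol-1-yl gives a 180-fold lower number from compound 1 to compound 3 (2.26 log units; beyond the scatter), which shows that a chloro-bearing phenyl ring at this point of the core goes with far tighter binding. No measurement here explains either step. The compounds shown leave open how fluoro, bromo, methyl or an amine would compare on the same carbon. They also leave open whether chloro would give a similar number on another carbon of the ring.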